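The compounds below may be only part of what the source reports. "The series", "measured", "known", "first", "only" and "open" are said of these compounds alone.

Working notes on the series. Going by the values given here, compound 1 `O=[N+]([O-])c1cccc(COc2ccc(OCCOCCNC3CCCC3)cc2)c1` is the only member with a numeric result: in a functional assay on SK-OV-3 cells (Homo sapiens) for inhibition, read by CCK-8 assay, with a stated time of 70 h (a higher number here means a weaker inhibitor, a lower number a stronger inhibitor), compound 1 gives 15400 nM. Compound 2 `c1ccc(COc2ccc(OCCOCCOC3CCCC3)cc2)cc1` returns no number at all. In this assay compound 2 gives only > 100000 nM, a limit of the assay and not a measured value. Among the compounds with values here, the comparison therefore rests on (the limit of > 100000 nM in this assay, at which 1 of the 2 values shown sits), and no step between two measured compounds is available to size any change. Compound 3 `O=[N+]([O-])c1ccccc1COc1ccc(OCCOCCNC2CCCC2)cc1` rearranges the same atoms as compound 1: 2-nitrophenyl in place of 3-nitrophenyl on a saturated chain carbon bound to an oxygen on an aromatic ring. With nothing measured to calibrate this move, in this assay the change is expected to be small, in neither direction beyond the usual scatter of repeated runs, the expected step being a 1.0-fold lower number from compound 1 to compound 3 (0.01 log units; within the scatter). On that basis the estimate for compound 3 in this assay is 15000 nM, with a plausible range from 5000 nM to 50000 nM.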

Compound 3, half-maximal inhibitory concentration: 5370 nM
Compound 3: the middle estimate sits 2.8-fold (0.45 log units) above what was measured; low and high end bracket the measured number.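

In this assay, 2-nitrophenyl in place of 3-nitrophenyl gives a 2.9-fold lower number from compound 1 to compound 3 (0.46 log units; beyond the scatter), so the group on a saturated chain carbon bound to an oxygen on an aromatic ring responds to where the nitro group stands, even with the atoms unchanged. Going by these compounds alone, this is the first step between two measured compounds and the first size for any change at this place, though a single pair sets no trend. No measured property in hand bears on why the two arrangements differ.

Still open, on these data alone, is how a nitrile or a carboxylic acid in place of the nitro group would read at this place. Compound 2 differs from compound 1 in more than one place and offers only a limit of the assay, so it sizes no change: the limit of > 100000 nM in this assay, at which 1 of the 3 values shown sits.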